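Chalcone-type series: swapping the aryl group on the carbonyl

The source may hold more compounds than are shown below. What is called first, only, known or untested is meant among the compounds shown, and "the series" means these compounds.

Measured so far in a functional assay on NCI-H460 cells (Homo sapiens) for inhibition, read by sulforhodamine B assay, with a stated time of 48 h; on this read-out higher numbers stand for weaker inhibition of growth and lower numbers for stronger inhibition of growth:
- compound 1, `COc1cc(-c2cc(/C=C/C(=O)c3ccc(Cl)c(Cl)c3)[nH]n2)cc(OC)c1OC`: 36600 nM
- compound 2, `COc1ccc(-c2cc(/C=C/C(=O)c3ccc(N)cc3)[nH]n2)cc1OC`: 4530 nM
- compound 3, `COc1ccc(-c2cc(/C=C/C(=O)c3cc(OC)c(OC)c(OC)c3)[nH]n2)cc1OC`: 3600 nM

Compound 1 stands at the highest number of the three, that is, the weakest inhibition of growth seen here. Compound 2 and compound 3 both sit well below it, beyond the scatter, while their own values lie close to each other. Both of these carry methoxy-bearing aryl groups at each end of the shared core, whereas compound 1 carries a 3,4-dichlorophenyl on the carbonyl carbon.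

Compound 4, `COc1ccc(C(=O)/C=C/c2cc(-c3cc(OC)c(OC)c(OC)c3)n[nH]2)cc1OC`, has not yet been measured in this assay. It differs from compound 1 in one place:

3,4-dimethoxyphenyl in place of 3,4-dichlorophenyl on a carbonyl carbon

Given that compound 2 gives 4530 nM and compound 3 gives 3600 nM, both with methoxy-bearing aryl groups on the carbonyl carbon, the step from compound 1 to compound 4 is expected to be downward and beyond the scatter, about a 7.3-fold lower number from compound 1 to compound 4 (0.86 log units; beyond the scatter). The value of compound 4 is accordingly estimated at 5000 nM, with a range from 1500 nM to 18000 nM.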

Compound 4, concentration for total growth inhibition: 3330 nM
The estimate for compound 4 lay 1.5-fold (0.18 log units) above the measured number; low and high end bracket the measured number.
By their numbers in this assay, from the lowest: compounds 4, 3 and 2 (each within the scatter of the next); then compound 1.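

With the rest of the molecule unchanged, replacing 3,4-dichlorophenyl with 3,4-dimethoxyphenyl on the carbonyl carbon gives an 11-fold lower number from compound 1 to compound 4 (1.04 log units; beyond the scatter) in this assay and counts as a large step from a single change. The earlier gaps between compound 1 and compounds 2 and 3 came with differences in more than one place, so they could not be assigned to the group on the carbonyl carbon alone. This pair shows that the position itself responds strongly to the aryl group it carries, though only these two groups are compared directly.

From the compounds shown here alone, the pair does not separate the loss of the two chlorines from the gain of the two methoxy groups, and the outcome with a plain phenyl or a phenyl bearing a carboxylic acid at this position remains open. No available data account for the size of this step.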